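The source may hold more compounds than are shown below. What is called first, only, known or untested is meant among the compounds shown, and "the series" means these compounds.

In an ADME assay on L02 cells (Homo sapiens) for cytotoxicity, read by MTT assay, with a stated time of 24 h (on this read-out higher numbers stand for weaker inhibition and lower numbers for stronger inhibition), compound 1 `CN1C/C(=C\c2cccnc2)C(=O)/C(=C/c2ccc(F)cc2Br)C1` gives 14400 nM, compound 2 `O=C1/C(=C/c2cccnc2)CN(S(=O)(=O)c2ccccc2)C/C1=C\c1ccccc1F` gives 15300 nM and compound 3 `O=C1/C(=C/c2cccnc2)CN(S(=O)(=O)c2ccccc2)C/C1=C\c1ccccc1C(F)(F)F` gives 12500 nM. These numbers lie within the scatter of one another, so compound 3 stands level with the other two. Compound 4 `O=C1/C(=C/c2cccnc2)CN(S(=O)(=O)c2ccc(Br)cc2)C/C1=C\c1ccccc1C(F)(F)F` differs from compound 3 in one place: bromo in place of hydrogen on an aromatic carbon, which turns phenylsulfonyl into (4-bromophenyl)sulfonyl. Among the compounds with values here, no measured step touches that group. Within the data shown here, the only step available, a 1.2-fold lower number from compound 2 to compound 3 (0.09 log units; within the scatter), is a different change, trifluoromethyl in place of fluoro on an aromatic carbon, and it stays within the scatter. No shift beyond the scatter is therefore expected in this assay. The expected step, a 1.1-fold lower number from compound 3 to compound 4 (0.06 log units; within the scatter), is an estimate resting on little evidence. Compound 4 is expected at 11000 nM, with an estimated range from 6000 nM to 20000 nM.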

Compound 4, half-maximal inhibitory concentration: 13300 nM
Compound 4: the middle estimate sits 1.2-fold (0.08 log units) below what was measured; low and high end bracket the measured number.
By their numbers in this assay, from the lowest: compounds 3, 4, 1 and 2 (each within the scatter of the next).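

In this assay, within the data shown here, the change from phenylsulfonyl to (4-bromophenyl)sulfonyl gives a 1.1-fold higher number from compound 3 to compound 4 (0.03 log units; within the scatter) and is the first reading of any change on this group. Adding bromo at this place leaves the number level with that of the parent compound, so this change shows no measurable shift. Nothing available explains this result. From the compounds shown here alone, whether an amine or a carboxylic acid at the same place would shift the number remains open. So does whether bromo would read alike on compound 2, which carries fluoro instead of trifluoromethyl.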